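Ethoxy on the shared core: the step to compound 4

A few compounds are considered here, and "the series" means these few. Any claim that something is new, unique, unknown or untested is made for them only; others in the source may bear on it.

Measured so far:
Compound 1 `COc1ccc2nc(NC(=O)CCCCC(=O)NO)sc2c1` gives 5.91 ug/mL in a functional assay on MCF7 cells (Homo sapiens) for cytotoxicity; a higher number here means a weaker inhibitor, a lower number a stronger inhibitor.
Compound 2 `O=C(CCCCCCC(=O)Nc1nc2ccccc2s1)NO` gives 6.61 ug/mL in this assay.
Compound 3 `O=C(CCCCC(=O)Nc1nc2ccc([N+](=O)[O-])cc2s1)NO` reaches only a limit, > 30 ug/mL in this assay.

Compound 2 holds the higher of the two numbers, with compound 1 nearest and within the scatter; the value of compound 3 is a limit of > 30 ug/mL in this assay, at which 1 of the 3 values shown sits, and not a number. Among the compounds with values here, the single measured step on the ring, an at least 5.0-fold higher number from compound 1 to compound 3 (0.70 log units; beyond the scatter), concerns a different change and does not carry over directly to compound 4.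

Compound 4 `CCOc1ccc2nc(NC(=O)CCCCCCC(=O)NO)sc2c1` differs from compound 2 by ethoxy in place of hydrogen on an aromatic carbon. Within the data shown here, compound 1 and compound 2 sit within the scatter of each other despite differing in both chain length and ring substitution, so no measured step points to a shift from adding an alkoxy group. The expected step of a 1.2-fold lower number from compound 2 to compound 4 (0.08 log units; within the scatter) is therefore none beyond the scatter. Compound 4 is estimated at 5.5 ug/mL, with a range from 2.5 ug/mL to 12 ug/mL.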

Compound 4, half-maximal inhibitory concentration: 11.6 ug/mL
Compound 4: the middle estimate sits 2.1-fold (0.32 log units) below what was measured, and the stated range covers the measured number.
By their numbers in this assay, from the lowest: compounds 1, 2 and 4 (each within the scatter of the next). At a limit, above all of these: compound 3.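

In this assay, ethoxy in place of hydrogen on an aromatic carbon of the shared core, with the chain of compound 2 kept, gives a 1.8-fold higher number from compound 2 to compound 4 (0.24 log units; within the scatter) and so stays within the scatter. Within the data shown here, this is the first direct reading against the unsubstituted ring: at this place, ethoxy on this chain brings no step beyond the scatter, whereas the nitro-for-methoxy change on the shorter chain gave an at least 5.0-fold higher number from compound 1 to compound 3 (0.70 log units; beyond the scatter) and remains a separate reading on a different chain. Nothing in the available data bears on a cause for this result.

From the compounds shown here alone, it remains open whether an amine or a carboxylic acid at this place would give a step beyond the scatter. Also open, going by these compounds, is whether a butoxy group would do so on either chain, or ethoxy on the shorter chain of compound 1.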